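The source may report more compounds than this note shows. Statements on the series, on what has been measured and on what is new or still open speak of the compounds shown alone.

This piece follows two compounds that share one core and differ only in the group carried on an amide-type nitrogen, and asks what a third member of the family might do.

Compound 1 `Cc1c(C)c2c(c(C)c1OC(=O)CCC(=O)O)CCC(C)(C(=O)NC1CC(C)(C)N([O])C(C)(C)C1)O2` was tested in a toxicity assay (LMTK cells) for cytotoxicity, with Mus musculus as the target, read by MTT assay, with a stated time of 72 h (on this read-out higher numbers stand for weaker inhibition and lower numbers for stronger inhibition), and gave > 300000 nM, which is a limit of the assay rather than a measured number. Compound 2 `Cc1c(C)c2c(c(C)c1OC(=O)CCC(=O)NC1CC(C)(C)N([O])C1(C)C)CCC(C)(C(=O)NC1CC(C)(C)N([O])C1(C)C)O2` was also tested in this assay, and for compound 2 the result > 300000 nM is likewise a limit. So compound 1 stands where every value shown stands: at the limit of > 300000 nM in this assay, at which 2 of the 2 values shown sit, with no finished number anywhere in the set to compare against.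

Compound 3 `Cc1c(C)c2c(c(C)c1OC(=O)CCC(=O)O)CCC(C)(C(=O)NC1CC(C)(C)N([O])C1(C)C)O2` has not yet been measured. It differs from compound 1 by a group of 10 heavy atoms (8 carbon, 1 nitrogen, 1 oxygen; one five-membered non-aromatic ring with 1 hetero atom) in place of a group of 11 heavy atoms (9 carbon, 1 nitrogen, 1 oxygen; one six-membered non-aromatic ring with 1 hetero atom), on an amide-type nitrogen. Within the data shown here, no step between two measured compounds is known here, so there is no measured change to lean on. Given that compound 1 sits at a limit > 300000 nM, the expectation is that the change from compound 1 to compound 3 amounts to a step that the limit leaves unreadable from compound 1 to compound 3, nothing beyond the scatter. Compound 3 is therefore expected to give about 400000 nM, somewhere between 150000 nM and 1000000 nM.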

Compound 3, half-maximal inhibitory concentration: > 300000 nM
Compound 3: a limit, no number; the forecaster's own chance of this, stated with the estimate: 85%; the middle value does not contradict the limit.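

Compound 3 also ends at a limit of the assay rather than a finished number, so the steps linking it to compound 1 and compound 2 cannot be read: the limit of > 300000 nM in this assay, at which 3 of the 3 values shown sit. The compounds shown leave open how far each one lies from that limit in this assay, and whether their differing groups change the read-out at all.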